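Bromo to methyl: a small swap on compound 1

This account rests on a few compounds, and the source may have more. Where it says the series, first, only, none or still open, it means among the compounds named here.

Among the compounds with values here, only two compounds have numbers so far. In a functional assay on Jurkat cells (Homo sapiens) for cytotoxicity, read by MTT assay, with a stated time of 24 h (a lower number here means that less compound is needed, a higher number that more compound is needed for the effect), compound 1 (`CCOC(=O)c1cc([Se]c2ccccc2)c2cc(Br)ccc2n1`) gives 20800 nM and stands lowest of the two, while compound 2 (`CCOC(=O)c1cc([Se]c2ccc3ccccc3c2)c2cc(OC)ccc2n1`) gives 50700 nM as its reading, a gap beyond the usual scatter. These two compounds differ in more than one place, so their gap cannot be pinned on any single group.

Next comes compound 3 (`CCOC(=O)c1cc([Se]c2ccccc2)c2cc(C)ccc2n1`), not yet measured, which keeps the core of compound 1 but carries methyl in place of bromo on an aromatic carbon. Within the data shown here, no measured pair shows this swap, so the data offer no direct guide. The only yardstick is the spread from compound 1 at 20800 nM to compound 2 at 50700 nM on the scale of this assay alone. The estimated 1.4-fold higher number from compound 1 to compound 3 (0.16 log units; within the scatter) is expected to be small, toward a higher number, and it may well stay within the scatter. For compound 3 the expected value is 30000 nM with an estimated range from 12000 nM to 70000 nM in this measurement.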

Compound 3, half-maximal effective concentration: 15300 nM
Compound 3: the middle estimate sits 2.0-fold (0.29 log units) above what was measured, and the stated range covers the measured number.
By their numbers in this assay, from the lowest: compounds 3 and 1 (each within the scatter of the next); then compound 2.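

Within the data shown here, this is the first pair of compounds that differ in only one place, so a single swap can now be read on its own. In this assay the change to methyl in place of bromo on an aromatic carbon gives a clean step (a 1.4-fold lower number from compound 1 to compound 3 (0.13 log units; within the scatter)). That step lies within the scatter, so at this position on the six-membered aromatic ring of carbon only, the two groups cannot be told apart by this measurement. No measurement shown here bears on why the two compounds read alike.

The compounds shown leave open whether a group of another kind on this same carbon, such as an amine, a carboxylic acid or a longer chain, would move the number beyond the scatter. Compound 2 still differs from compound 1 and from compound 3 in more than one place, so its number cannot yet be tied to any one group.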